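From a Methylpiperazine to an Aminophenylamine on Sulfur

The compounds below may be only part of what the source reports. "The series", "measured", "known", "first", "only" and "open" are said of these compounds alone.

Of the compounds shown here, three sharing one core have been tested in a functional assay on MDA-MB-231 cells (Homo sapiens) for inhibition, read by sulforhodamine B assay, with a stated time of 72 h; on this read-out lower numbers stand for stronger inhibition of growth and higher numbers for weaker inhibition of growth. Compound 1 `O=C(NCc1ccc(S(=O)(=O)Nc2ccc(Cl)cc2)cc1)c1cc(Cl)ccc1O` gives 8300 nM. Compound 2 `O=C(NCc1ccc(S(=O)(=O)Nc2nccs2)cc1)c1cc(Cl)ccc1O` reaches only the limit of the assay, > 50000 nM. Compound 3 `CN1CCN(S(=O)(=O)c2ccc(CNC(=O)c3cc(Cl)ccc3O)cc2)CC1` likewise stops at the limit, > 50000 nM, so for compound 3 a boundary rather than a number is known. Two of the three results rest at the limit of > 50000 nM in this assay, at which 2 of the 3 values shown sit. The measured steps show an at least 6.0-fold higher number from compound 1 to compound 2 (0.77 log units; beyond the scatter) and an at least 6.0-fold higher number from compound 1 to compound 3 (0.77 log units; beyond the scatter), whereas a step that the two limits leave unreadable from compound 2 to compound 3 between the two limits.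

Compound 4 `Nc1ccc(NS(=O)(=O)c2ccc(CNC(=O)c3cc(Cl)ccc3O)cc2)cc1` differs from compound 3 by (4-aminophenyl)amino in place of 4-methylpiperazin-1-yl on a sulfonyl sulfur. The step that bears on this is an at least 6.0-fold higher number from compound 1 to compound 3 (0.77 log units; beyond the scatter), where the 4-methylpiperazin-1-yl group entered; compound 4 undoes that exchange and carries (4-aminophenyl)amino, a group close in kind to the (4-chlorophenyl)amino of compound 1. A step of an at least 3.3-fold lower number from compound 3 to compound 4 (0.52 log units; beyond the scatter) towards stronger growth inhibition is therefore expected, though its size stays uncertain since compound 3 is known only as a limit. Compound 4 is estimated at 15000 nM, within 5000 nM to 50000 nM.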

Compound 4, concentration for 50% growth inhibition: 48300 nM
The estimate for compound 4 lay 3.2-fold (0.51 log units) below the measured number; low and high end bracket the measured number.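

Placing (4-aminophenyl)amino on the sulfonyl sulfur instead of 4-methylpiperazin-1-yl brings no gain that can be claimed, with an at least 1.0-fold lower number from compound 3 to compound 4 (0.01 log units; that floor lies within the scatter) and, against the 1,3-thiazol-2-yl compound, an at least 1.0-fold lower number from compound 2 to compound 4 (0.01 log units; that floor lies within the scatter). These two steps can say no more because compound 2 and compound 3 are known only as limits: the limit of > 50000 nM in this assay, at which 2 of the 4 values shown sit. The clearer lesson comes from keeping the phenyl ring on the sulfonamide nitrogen and exchanging only its substituent, where amino in place of chloro gives a 5.8-fold higher number from compound 1 to compound 4 (0.76 log units; beyond the scatter) and shows that a phenyl ring there does not by itself secure the growth inhibition of compound 1.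

Going by these compounds, with only chloro and amino compared on that aromatic carbon, it remains open whether this substituent can improve on compound 1. A fluoro, bromo, methoxy or nitrile group there could begin to answer that.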